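Aryl swap on the shared core: compound 3 to compound 4

A few compounds are considered here, and "the series" means these few. Any claim that something is new, unique, unknown or untested is made for them only; others in the source may bear on it.

The series shares one core and varies the group on the five-membered aromatic ring. Compound 1 `Cc1c(NCc2nnc(COc3ccccc3)o2)c(=O)n(-c2ccccc2)n1C` carries phenoxymethyl there and in a physicochemical assay for lipophilicity, measured as octanol-water partition (on this read-out higher numbers stand for higher lipophilicity and lower numbers for lower lipophilicity), compound 1 gives 0.98. Compound 2 `Cc1c(NCc2nnc(-c3ccc(Cl)cc3)o2)c(=O)n(-c2ccccc2)n1C` carries 4-chlorophenyl and in this assay compound 2 gives 2.7. Compound 3 `COc1ccc(-c2nnc(CNc3c(C)n(C)n(-c4ccccc4)c3=O)o2)cc1` carries 4-methoxyphenyl and in this assay compound 3 gives 2.07, the second highest of the three numbers: below compound 2 by a number 0.63 log units lower from compound 2 to compound 3 (beyond the scatter) and above compound 1 by a number 1.09 log units higher from compound 1 to compound 3 (beyond the scatter). The two aryl replacements of phenoxymethyl are both large, a number 1.72 log units higher from compound 1 to compound 2 (beyond the scatter) and a number 1.09 log units higher from compound 1 to compound 3 (beyond the scatter).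

Compound 4 `Cc1ccccc1-c1nnc(CNc2c(C)n(C)n(-c3ccccc3)c2=O)o1` differs from compound 3 in one place: 2-methylphenyl in place of 4-methoxyphenyl on an aromatic carbon. Among the measured compounds shown here, no measured step exchanges methoxy for methyl, so the nearest guide is the pair compound 2 and compound 3, where replacing chloro by methoxy on the same ring gave a number 0.63 log units lower from compound 2 to compound 3 (beyond the scatter). Taking methoxy away and placing a methyl on the ring is expected to move the number back toward compound 2, by a modest step of about a number 0.53 log units higher from compound 3 to compound 4 (beyond the scatter) in this assay. Compound 4 is therefore estimated at 2.6, with a range from 2.2 to 3.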

Compound 4, partition coefficient: 2.38
For compound 4 the middle estimate is 0.22 log units above the measured one; low and high end bracket the measured number.
By their numbers in this assay, from the lowest: compound 1; then compound 3; then compound 4; then compound 2.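

With 2-methylphenyl on this aromatic carbon of the shared core, a third aryl group can be set against phenoxymethyl: in this assay the exchange gives a number 1.40 log units higher from compound 1 to compound 4 (beyond the scatter), so compound 2, compound 3 and compound 4 all stand above compound 1, with none of the listed compounds going against this. The new group also falls inside the span set by the two earlier aryl groups, with a number 0.31 log units higher from compound 3 to compound 4 (beyond the scatter) and a number 0.32 log units lower from compound 2 to compound 4 (beyond the scatter), so moving from a substituent named at the 4 place of the phenyl to one named at the 2 place does not take the number outside that span. No supporting data bear on why these steps have their sizes.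

2-methylphenyl differs from 4-methoxyphenyl and 4-chlorophenyl both in the substituent and in where it stands on the phenyl, so the compounds shown cannot separate those two changes, and a 4-methylphenyl or 2-methoxyphenyl group would be needed to do so. Also open, going by these compounds, is whether the aryl-over-phenoxymethyl order would hold for a phenyl carrying an amine or a carboxylic acid, or for a longer chain at this position.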